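Trifluoromethyl for trifluoromethoxy in a diarylamine series

The source may hold more compounds than are shown below. What is called first, only, known or untested is meant among the compounds shown, and "the series" means these compounds.

Three diarylamines were tested in a functional assay on NALM-6 cells (Homo sapiens) for cytotoxicity, with a stated time of 72 h; a higher number here means that more compound is needed for the effect, a lower number that less compound is needed. Compound 1 `C=C[C@@](C)(/C=C/c1ccc(Nc2cccc(OC(F)(F)F)c2)cc1)CCC=C(C)C` carries a trifluoromethoxy group on its outer ring. In this assay compound 1 gives > 43400 nM, which is a limit of the assay and not a number. Compound 2 `C=C[C@@](C)(/C=C/c1ccc(Nc2ccc(OC(F)(F)F)cc2)cc1)CCC=C(C)C` has the same atoms joined differently, and the difference between the two cores is not broken down here. In this assay compound 2 gives > 43400 nM, again a limit. Compound 3 `C=C[C@@](C)(/C=C/c1ccc(Nc2ccc(C(F)(F)F)cc2)cc1)CCC=C(C)C` differs from compound 2 by trifluoromethyl in place of trifluoromethoxy on an aromatic carbon. In this assay compound 3 gives > 43400 nM, once more a limit. The step that the two limits leave unreadable from compound 2 to compound 3 cannot be read because of the limit of > 43400 nM in this assay, at which 3 of the 3 values shown sit.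

Compound 4 `C=C[C@@](C)(/C=C/c1ccc(Nc2cccc(C(F)(F)F)c2)cc1)CCC=C(C)C` has not yet been measured. It differs from compound 1 by trifluoromethyl in place of trifluoromethoxy on an aromatic carbon. This is the same kind of change as that from compound 2 to compound 3, though the place is not identical: in compound 3 the entering group stands para to a large group, while in compound 4 it stands meta to a large group. Since every measured value sits at the limit, nothing in the data points to a readable difference. The expected step is a step that the limit leaves unreadable from compound 1 to compound 4, resting on the three limits. Compound 4 is accordingly expected to give 60000 nM, with a range from 30000 nM to 150000 nM, most likely reported as a limit again.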

Compound 4, half-maximal effective concentration: > 43400 nM
Compound 4: no number, only a limit; the forecaster's own chance of this, stated with the estimate: 85%; the middle value does not contradict the limit.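

In this assay compound 4 gives > 43400 nM, a limit of the assay and not a number. No new step can be read between compound 1 and compound 4, because the result gives only a limit for each: the limit of > 43400 nM in this assay, at which 4 of the 4 values shown sit.

The compounds shown leave open whether trifluoromethyl in place of trifluoromethoxy changes anything in this assay, and how the four compounds would rank against one another.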